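The source may hold more compounds than are shown below. What is called first, only, known or untested is meant among the compounds shown, and "the series" means these compounds.

Measured compounds:
- compound 1, `COc1ccc([C@@H]2C/C(=N/OCc3cn(-c4ccccc4CO)nn3)c3cc(CC=C(C)C)c(OC)cc3O2)cc1`: 100%
- compound 2, `COc1cc2c(cc1CC=C(C)C)C(=O)C[C@@H](c1ccc(Oc3ccccc3)cc1)O2`: 69%
- compound 3, `COc1cc2c(cc1CC=C(C)C)C(=O)C[C@@H](c1ccc(Oc3cccc([N+](=O)[O-])c3)cc1)O2`: 53%

In a functional assay on MCF7 cells (Homo sapiens) for inhibition, read by sulforhodamine B assay, with a stated time of 48 h, tested at 50 uM (a higher number here means more inhibition of growth at the concentration tested, a lower number less inhibition of growth), compound 1 gives 100%, the highest of the three numbers. Compound 2 gives 69% and compound 3 gives 53%, so compound 1 stands well clear of both, and both gaps lie beyond the scatter.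

Compound 4, `COc1ccc([C@@H]2C/C(=N/OCc3cn(-c4ccc(C#N)cc4)nn3)c3cc(CC=C(C)C)c(OC)cc3O2)cc1`, has not been measured. It differs from compound 1 in one place: 4-cyanophenyl in place of 2-(hydroxymethyl)phenyl on an aromatic nitrogen.

Within the data shown here, only one measured step exists, and it concerns a different ring and a different substitution: a number 16 percentage points lower from compound 2 to compound 3 (beyond the scatter). It shows that adding a polar group to an outer aromatic ring in this series gave a modest drop. The change from compound 1 to compound 4 also alters an outer aromatic ring, trading a donor for a nitrile. Compound 1 already sits at the top of this assay, so an increase cannot appear; a modest decrease or no change beyond the scatter is expected.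

Compound 4 is therefore estimated at 88%, within 65% to 100%, an expected step of a number 12 percentage points lower from compound 1 to compound 4 (beyond the scatter).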

Compound 4, percent growth inhibition at one concentration: 40%
The estimate for compound 4 lay 48 percentage points above the measured number, and the stated range ends above it.
By their numbers in this assay, from the lowest: compound 4; then compound 3; then compound 2; then compound 1.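

The group on the aromatic nitrogen of the five-membered ring matters greatly in this series: in this assay the exchange of 2-(hydroxymethyl)phenyl for 4-cyanophenyl gives a number 60 percentage points lower from compound 1 to compound 4 (beyond the scatter) and leaves the rest of the molecule untouched. Among these compounds, the earlier step lay on a different outer ring, so this is the first sign that growth inhibition depends on what this position carries. The entering group has no hydrogen-bond donor and adds a triple bond, but nothing available ties the loss to either difference.

As far as these compounds go, whether the result follows the departure of the hydroxymethyl group, the arrival of the nitrile or the different place on the phenyl ring stays open. How a plain phenyl, a 2-(aminomethyl)phenyl or a 2-carboxyphenyl group would read at this position is also unknown.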